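Cis-linked butylphenyl alkyne: expected antiproliferative activity

The source may hold more compounds than are shown below. What is called first, only, known or untested is meant among the compounds shown, and "the series" means these compounds.

Four compounds share one core: a phthalimide joined through a four-carbon linker to a uracil that bears an alkyne. Compound 3 `O=C1c2ccccc2C(=O)N1C/C=C\Cn1cc(C#CCCc2ccccc2)c(=O)[nH]c1=O` carries a phenethyl group on that alkyne. In a functional assay on MCF7 cells (Homo sapiens) for antiproliferative activity, read by MTT assay, with a stated time of 3 days (on this read-out lower numbers stand for stronger inhibition and higher numbers for weaker inhibition), compound 3 gives > 100000 nM, which is a limit of the assay rather than a number. Compound 1 `O=C1c2ccccc2C(=O)N1C/C=C\Cn1cc(C#Cc2ccc(Br)cc2)c(=O)[nH]c1=O` gives > 100000 nM in this assay, also a limit. Hence the step that the two limits leave unreadable from compound 1 to compound 3 cannot be read; two of the three values sit at the limit of > 100000 nM in this assay, at which 2 of the 3 values shown sit. Compound 2 `CCCCc1ccc(C#Cc2cn(C/C=C/CN3C(=O)c4ccccc4C3=O)c(=O)[nH]c2=O)cc1`, which differs from the others in the shape of its linker, gives 44000 nM in this assay, a measured number.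

Compound 4 `CCCCc1ccc(C#Cc2cn(C/C=C\CN3C(=O)c4ccccc4C3=O)c(=O)[nH]c2=O)cc1` is obtained from compound 3 by the change (4-butylphenyl in place of phenethyl on a triple-bonded carbon). For the measured compounds named here, no measured step covers this exact change, since the only comparable pair is unreadable. Going by the values given here, compound 2 carries the same 4-butylphenyl group as compound 4 on a differently shaped linker, and its value is the one number available. Compound 4 is therefore expected to land near that number, with the step of an at least 1.6-fold lower number from compound 3 to compound 4 (0.22 log units; that floor lies within the scatter) estimated as modest and with a real chance of another limit. The estimate for compound 4 in this assay is 60000 nM, expected to fall between 20000 nM and 200000 nM.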

Compound 4, half-maximal inhibitory concentration: 43000 nM
Beside the measured number, compound 4's estimate is 1.4-fold (0.14 log units) above it, within the range that was stated.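

In this assay, 4-butylphenyl in place of phenethyl on a triple-bonded carbon gives an at least 2.3-fold lower number from compound 3 to compound 4 (0.36 log units; beyond the scatter), so the read-out does respond to the group carried at this position. Butyl in place of bromo on an aromatic carbon gives an at least 2.3-fold lower number from compound 1 to compound 4 (0.36 log units; beyond the scatter), which shows that a change at the far end of the aryl group can also matter, even though the rest of the molecule stays the same. Turning the linker double bond from E to Z gives a 1.0-fold lower number from compound 2 to compound 4 (0.01 log units; within the scatter), so the shape of the linker shows no effect here, and this pair tests that one feature alone: the fact that compounds 2 and 4 differ only in the configuration as drawn.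

On these data alone, compound 1 and compound 3 each stand at a limit, so the full size of the two steps that start from them stays open: the limit of > 100000 nM in this assay, at which 2 of the 4 values shown sit. As far as these compounds go, whether an amine, a carboxylic acid or a longer chain such as octyl in place of butyl on that aromatic carbon would bring a lower number than that of compound 4 also stays open.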